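Aryl for arylmethyl on the ring nitrogen of compound 1

This account rests on a few compounds, and the source may have more. Where it says the series, first, only, none or still open, it means among the compounds named here.

Antiproliferative effect in this series is followed in a functional assay on MGC-803 cells (Homo sapiens) for antiproliferative activity, read by CCK-8 assay, with a stated time of 72 h, tested at 8 uM; a lower number here means a weaker effect, a higher number a stronger effect of the compound at the concentration tested. Compound 1 `Nc1ccccc1NC(=O)c1ccc(CSC(=S)N2CCN(Cc3ccccn3)CC2)cc1` gives 65.2% there, the second highest of the three numbers in hand. Compound 3 `Nc1ccccc1NC(=O)c1ccc(CSC(=S)N2CCCc3ccccc32)cc1` gives 87.5%, a stronger effect than compound 1 by a margin beyond the usual scatter, and compound 2 `Nc1ccccc1NC(=O)c1ccc(CSC(=S)N2CCc3ccc([N+](=O)[O-])cc32)cc1` gives 39.6%, a weaker effect than compound 1, again beyond the scatter. Among the compounds with values here, compounds 2 and 3 each differ from compound 1 in more than one place, so no single-point step between measured compounds exists to calibrate the change considered next.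

Compound 4 `Nc1ccccc1NC(=O)c1ccc(CSC(=S)N2CCN(c3cccnc3)CC2)cc1` differs from compound 1 as follows: pyridin-3-yl in place of (pyridin-2-yl)methyl on an amine nitrogen in a ring. Both groups carry the same ring type and the same donor and acceptor count as given above; only the group size and the way it sits on the amine nitrogen change. With no measured step of this kind in the set, the expectation for the move from compound 1 to compound 4 is a step of modest size, a number 5.2 percentage points lower from compound 1 to compound 4 (within the scatter), not clearly beyond the scatter and of uncertain direction. Compound 4 is therefore estimated at 60% in this assay, with a likely range from 40% to 80%.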

Compound 4, a percentage reported as inhibition, at one concentration (the size of the read-out at that concentration, not a potency): 76.9%
Compound 4: the middle estimate sits 16.9 percentage points below what was measured; the measured number falls inside the stated range.
By their numbers in this assay, from the lowest: compound 2; then compound 1; then compound 4; then compound 3.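

In this assay, within the data shown here, the step on the amine nitrogen of the six-membered ring is the first single-point change that can be read: pyridin-3-yl in place of (pyridin-2-yl)methyl gives a number 11.7 percentage points higher from compound 1 to compound 4 (beyond the scatter). This shows that the activity at this position responds to how the aromatic ring is attached, even though both groups carry the same ring type and the same donor and acceptor counts, so those counts alone do not set the read-out here. No measured information in hand explains the step, which also combines two changes, the loss of the methyl link and the move from a pyridin-2-yl to a pyridin-3-yl ring.

As far as these compounds go, it remains open which of these two changes goes with the step; pyridin-2-yl or (pyridin-3-yl)methyl on the same amine nitrogen would separate them. From the compounds shown here alone, it is also open whether the pyridine ring nitrogen matters at all at this position, which phenyl or benzyl on the same amine nitrogen would address.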